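A few compounds are considered here, and "the series" means these few. Any claim that something is new, unique, unknown or untested is made for them only; others in the source may bear on it.

Of the compounds shown here, two of the shared core have numbers so far. In a functional assay on MDA-MB-435 cells (Homo sapiens) for inhibition, read by sulforhodamine B assay, with a stated time of 48 h (a higher number here means a weaker inhibitor of growth, a lower number a stronger inhibitor of growth), compound 1 `COc1cc(-c2nn(-c3cccc(NC(=O)Nc4cc(C(F)(F)F)cc(C(F)(F)F)c4)c3)cc2-c2ccncc2)ccc1Cl` gives 1990 nM. In this assay compound 2 `COc1cc(-c2nn(-c3cccc(NC(=O)c4cccc(C(F)(F)F)c4)c3)cc2-c2ccncc2)ccc1Cl` gives 1770 nM; the two numbers lie within the usual scatter of each other, so on what is known compound 2 stands level with compound 1. Compound 3 `COc1cc(-c2nn(-c3cccc(NC(=O)Nc4ccc(Cl)c(Cl)c4)c3)cc2-c2ccncc2)ccc1Cl` has not yet been measured in this assay. It differs from compound 2 in one place: (3,4-dichlorophenyl)amino in place of 3-(trifluoromethyl)phenyl on a carbonyl carbon. Compound 1 also carries a carbamoyl of this kind, and compound 1 and compound 2 show no difference beyond the scatter. Among the compounds with values here, no step between measured compounds with exactly this change exists, so the step from compound 2 to compound 3 is expected to be a 1.1-fold lower number from compound 2 to compound 3 (0.04 log units; within the scatter), a shift expected to stay within the scatter. Compound 3 is accordingly estimated at 1600 nM, with a range from 600 nM to 4000 nM.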

Compound 3, concentration for total growth inhibition: 2390 nM
For compound 3 the middle estimate is 1.5-fold (0.17 log units) below the measured one; the range from low to high includes it.
By their numbers in this assay, from the lowest: compounds 2, 1 and 3 (each within the scatter of the next).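

Exchanging 3-(trifluoromethyl)phenyl for (3,4-dichlorophenyl)amino on the carbonyl carbon gives in this assay a 1.4-fold higher number from compound 2 to compound 3 (0.13 log units; within the scatter) and so leaves no readable shift at this position. The exchange alters the aromatic substituents and brings in an amino hydrogen-bond donor at once, and this single step cannot separate the two changes. No measurement at hand bears on this result.

All compounds shown keep a substituted aromatic ring of carbon only beyond the carbonyl, so the response to an unsubstituted phenyl, a dimethylamino group or a longer alkyl chain there remains open. Going by these compounds, it also remains open whether a carboxylic acid on this ring would carry the number beyond the scatter in this assay in either direction.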